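The compounds below may be only part of what the source reports. "The series", "measured", "known", "first", "only" and "open" are said of these compounds alone.

Compound 3 `COc1ccc(C(=O)/C=C/c2cc(-c3cc(OC)c(OC)c(OC)c3)n[nH]2)cc1` stands second highest of the three numbers in a functional assay on SK-OV-3 cells (Homo sapiens) for cytotoxicity, read by sulforhodamine B assay, with a stated time of 48 h, tested at 10 uM (on this read-out higher numbers stand for a weaker effect at the one concentration tested and lower numbers for a stronger effect), where compound 3 gives 18%. Its nearest neighbour is compound 1 `COc1cc(-c2cc(/C=C/C(=O)c3ccc(Cl)c(Cl)c3)[nH]n2)cc(OC)c1OC`, which in this assay gives 26%, the gap being a number 8 percentage points lower from compound 1 to compound 3 (within the scatter). Furthest away is compound 2 `COc1ccc(C(=O)/C=C/c2cc(-c3cc(OC)c(OC)c(OC)c3)n[nH]2)cc1OC`, which in this assay gives -12%, separated by a number 30 percentage points higher from compound 2 to compound 3 (beyond the scatter).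

Compound 4 `COc1cc(-c2cc(/C=C/C(=O)c3ccc(F)c(F)c3)[nH]n2)cc(OC)c1OC` differs from compound 3 by 3,4-difluorophenyl in place of 4-methoxyphenyl on a carbonyl carbon. Going by the values given here, two measured steps bear on this position on the carbonyl carbon: the swap of a 3,4-dichlorophenyl for a 4-methoxyphenyl gave a number 8 percentage points lower from compound 1 to compound 3 (within the scatter), while the swap for a 3,4-dimethoxyphenyl gave a number 38 percentage points lower from compound 1 to compound 2 (beyond the scatter). Compound 4 carries a dihalophenyl at this place, as compound 1 does, and because a number 8 percentage points lower from compound 1 to compound 3 (within the scatter) stayed within the scatter, the return from the 4-methoxyphenyl to a dihalophenyl is not expected to move the read-out beyond the scatter. Compound 4 is therefore expected to give about 22%, somewhere between 5% and 40%. For compound 4 the expected step is a number 4 percentage points higher from compound 3 to compound 4 (within the scatter), a change within the scatter.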

Compound 4, a percentage reported as activity, at one concentration (the size of the read-out at that concentration, not a potency): 17%
The estimate for compound 4 lay 5 percentage points above the measured number, within the range that was stated.
By their numbers in this assay, from the lowest: compound 2; then compounds 4, 3 and 1 (each within the scatter of the next).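

Compound 4 shows that 3,4-difluorophenyl on this carbonyl carbon cannot be told apart from the two groups nearest to it in this assay, with a number 9 percentage points lower from compound 1 to compound 4 (within the scatter) and a number 1 percentage points lower from compound 3 to compound 4 (within the scatter). Going by these compounds alone, it also shows that the 3,4-dimethoxyphenyl of compound 2 stands apart from a third group on this carbon, with a number 29 percentage points higher from compound 2 to compound 4 (beyond the scatter), so among the four compounds only that group gives a separation beyond the scatter, while the single methoxy of compound 3 does not. Nothing shown here gives a cause for these steps.

As far as these compounds go, it remains open how a phenyl ring carrying an amine or a carboxylic acid would read at this carbonyl carbon. From the compounds shown here alone, it also remains open whether the separation of compound 2 would hold with a longer alkoxy chain in place of its methoxy groups.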